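This account rests on a few compounds, and the source may have more. Where it says the series, first, only, none or still open, it means among the compounds named here.

In a functional assay on DU-145 cells (Homo sapiens) for inhibition, read by trypan blue exclusion, with a stated time of 72 h (a higher number here means a weaker inhibitor, a lower number a stronger inhibitor), compound 1 `Cn1c(=O)c(S(=O)(=O)c2ccc(F)cc2F)cc2cnc(Nc3ccc4[nH]ncc4c3)nc21` gives 30000 nM while compound 2 `CCn1c(=O)c(S(=O)(=O)c2ccc(F)cc2F)cc2cnc(Nc3ccc4[nH]ccc4c3)nc21` gives 750 nM and compound 3 `Cn1c(=O)c(S(=O)(=O)c2ccc([N+](=O)[O-])cc2F)cc2cnc(Nc3ccc4[nH]ccc4c3)nc21` gives 400 nM in the same read-out. Compound 2 thus stands within the scatter of compound 3, and its gap to compound 1 lies beyond the scatter. Compound 4 `O=c1c(S(=O)(=O)c2ccc(F)cc2F)cc2cnc(Nc3ccc4[nH]ccc4c3)nc2n1C1CCCCC1` carries cyclohexyl in place of ethyl on an aromatic nitrogen and is otherwise identical to compound 2. Among the compounds with values here, no measured pair isolates a change at that nitrogen, so no shift beyond the scatter is expected in this assay and any drift is expected toward a lower number. The expected step of a 1.5-fold lower number from compound 2 to compound 4 (0.18 log units; within the scatter) stays small on that reading. Compound 4 is estimated at 500 nM with an expected range from 100 nM to 3000 nM in this series.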

Compound 4, half-maximal inhibitory concentration: 10000 nM
Beside the measured number, compound 4's estimate is 20-fold (1.30 log units) below it, outside the stated range (above it).
By their numbers in this assay, from the lowest: compounds 3 and 2 (each within the scatter of the next); then compound 4; then compound 1.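

In this assay, within the data shown here, the group on this aromatic nitrogen matters: cyclohexyl in place of ethyl gives a 13-fold higher number from compound 2 to compound 4 (1.12 log units; beyond the scatter), the only single-place change read so far. Neither group carries hydrogen-bond donors, hydrogen-bond acceptors or a net charge, so the step arises without a change in any of these counts. Nothing measured here accounts for the step. Going by these compounds, how the number moves between ethyl and cyclohexyl stays open, for instance with a propyl chain or a cyclopropyl ring on that nitrogen. Also open, on these data alone, is whether a cyclohexyl ring bearing an amine behaves like the plain ring.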